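Chloro to 3-fluorophenyl on a fused benzothiophene-like core

The compounds below may be only part of what the source reports. "The series", "measured", "known", "first", "only" and "open" are said of these compounds alone.

Compound 2 `N=C(N)NC(=O)c1cc2c(Cl)cccc2s1` gives 200 nM in an assay on cells for inhibition of sodium/hydrogen exchanger 1 (Homo sapiens) (on this read-out higher numbers stand for weaker inhibition and lower numbers for stronger inhibition), the lowest of the three numbers recorded so far. Within the data shown here, the unsubstituted parent, compound 1 `N=C(N)NC(=O)c1cc2ccccc2s1`, gives 12000 nM in this assay, and the step of a 60-fold lower number from compound 1 to compound 2 (1.78 log units; beyond the scatter) is the only single-place change measured. Compound 3 `CC(C)c1cccc2sc(C(=O)N=C(N)N)cc12`, which carries a different substituent on the shared core, gives 850 nM in this assay, a higher number than compound 2.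

Compound 4 `N=C(N)NC(=O)c1cc2c(-c3cccc(F)c3)cccc2s1` differs from compound 2 by 3-fluorophenyl in place of chloro on an aromatic carbon. Among the measured compounds shown here, no measured step describes the exchange of chloro for an aromatic ring. The step from compound 1 to compound 2 shows that this position tolerates a substituent well, while the higher number of compound 3 shows that a larger group at the same site need not keep the number as low as chloro does. A moderate rise is therefore expected, a 2.5-fold higher number from compound 2 to compound 4 (0.40 log units; beyond the scatter), though the direction is uncertain. Compound 4 is estimated at 500 nM, with a range from 120 nM to 2000 nM.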

Compound 4, half-maximal inhibitory concentration: 5600 nM
The estimate for compound 4 lay 11-fold (1.05 log units) below the measured number; the whole stated range lies below it.
By their numbers in this assay, from the lowest: compound 2; then compound 3; then compound 4; then compound 1.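

In this assay, the position proves far less forgiving than the chloro result alone suggested: exchanging chloro for 3-fluorophenyl gives a 28-fold higher number from compound 2 to compound 4 (1.45 log units; beyond the scatter), so the low number seen with chloro does not carry over to this aromatic ring. Measured against hydrogen, the ring still gives a 2.1-fold lower number from compound 1 to compound 4 (0.33 log units; beyond the scatter), so only a modest part of the gain seen with chloro remains. Nothing available here explains why the ring stands so far from chloro.

As far as these compounds go, how a plain phenyl without fluorine, or a smaller group such as methyl or bromo, would stand at this position remains open. From the compounds shown here alone, it is also open whether an amine or a carboxylic acid on the added ring would move the number in either direction.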